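The source may report more compounds than this note shows. Statements on the series, on what has been measured and on what is new or still open speak of the compounds shown alone.

Measured compounds in a functional assay on MCF7 cells (Homo sapiens) for inhibition, read by MTT assay, with a stated time of 48 h; on this read-out higher numbers stand for weaker inhibition and lower numbers for stronger inhibition:
- compound 1, `COc1cc(-c2cc(/C=C/C(C)=O)[nH]n2)cc(OC)c1OC`: 20100 nM
- compound 2, `COc1cc(-c2cc(/C=C3\Cc4ccccc4C3=O)[nH]n2)cc(OC)c1OC`: 4800 nM
- compound 3, `COc1cc(-c2cc(/C=C3\CCc4ccccc4C3=O)[nH]n2)cc(OC)c1OC`: 8500 nM

Compound 1 gives the highest of the three numbers in this assay, that is, the weakest inhibition. Compound 3 comes nearest to it, yet its number still lies beyond the scatter of compound 1, and compound 2 lies furthest away, also beyond the scatter. In both of those compounds the carbonyl carbon of the enone is bound into a fused ring system rather than carrying a methyl group, and both give lower numbers than compound 1.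

Compound 4, `COc1cc(-c2cc(/C=C/C(=O)c3ccc(Cl)cc3)[nH]n2)cc(OC)c1OC`, has not yet been measured in this assay. It differs from compound 1 in one place: 4-chlorophenyl in place of methyl on a carbonyl carbon. Acetyl thus becomes (4-chlorophenyl)carbonyl, so that the carbonyl carbon once more carries an aromatic ring, as it does in compound 2 and compound 3. On the strength of those two compounds, whose numbers fall below that of compound 1, compound 4 is expected to show a step to a lower number, of moderate size and beyond the scatter, a 3.1-fold lower number from compound 1 to compound 4 (0.49 log units; beyond the scatter). Compound 4 is therefore estimated at 6500 nM in this assay, with a likely range from 2000 nM to 20000 nM.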

Compound 4, half-maximal inhibitory concentration: 11600 nM
Compound 4: the middle estimate sits 1.8-fold (0.25 log units) below what was measured, and the stated range covers the measured number.
By their numbers in this assay, from the lowest: compounds 2, 3, 4 and 1 (each within the scatter of the next, the first and the last beyond it).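

In this assay, putting 4-chlorophenyl in place of methyl on a carbonyl carbon amounts to a 1.7-fold lower number from compound 1 to compound 4 (0.24 log units; within the scatter), so this change does not separate the two compounds on this read-out. Going by these compounds alone, this is the first direct reading at this position: the carbonyl carbon can carry this aromatic ring in an open enone, yet the ring alone brings no step beyond the scatter, whereas compound 2 and compound 3 differ from compound 1 in more than one place and so could not speak to this single change. No measured property of either group is available to account for this result.

The compounds shown leave open whether the chlorine contributes anything, since a plain phenyl group or a 4-methoxyphenyl group on the carbonyl carbon does not appear among them. They also leave open how a longer chain such as propyl, or an amine such as dimethylamino, would read at this same place, and so whether any single replacement of methyl there can give a step beyond the scatter.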